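From 3-nitrophenyl to 2-chloropyridin-3-yl at the assay limit

The compounds below may be only part of what the source reports. "The series", "measured", "known", "first", "only" and "open" are said of these compounds alone.

Measured so far in an ADME assay on MT4 cells (Homo sapiens) for cytotoxicity, read by MTT assay; on this read-out lower numbers stand for higher toxicity in this test and higher numbers for lower toxicity in this test:
Compound 1 `O=C1c2ccccc2C(=O)N1CCOC(=S)N(C(=O)c1cccc([N+](=O)[O-])c1)c1ccc(Cl)cc1` gives 18000 nM
Compound 2 `Cc1cccc2c1C(=O)N(CCOC(=S)N(C(=O)c1cccc([N+](=O)[O-])c1)c1ccc(Cl)cc1)C2=O` gives 44000 nM
Compound 3 `Cc1ccc2c(c1)C(=O)N(CCOC(=S)N(C(=O)c1cccc([N+](=O)[O-])c1)c1ccc(Cl)cc1)C2=O` gives > 100000 nM as a limit of the assay

Compound 3 stands highest of the three but has no exact number, as it sits at the limit of > 100000 nM in this assay, at which 1 of the 3 values shown sits, and is known only as a limit.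

Going by the values given here, the step to compound 4 `Cc1ccc2c(c1)C(=O)N(CCOC(=S)N(C(=O)c1cccnc1Cl)c1ccc(Cl)cc1)C2=O` puts 2-chloropyridin-3-yl in place of 3-nitrophenyl on a carbonyl carbon and so alters a part that no measured step has touched. Methyl in place of hydrogen on an aromatic carbon gave a 2.4-fold higher number from compound 1 to compound 2 (0.39 log units; beyond the scatter) and also an at least 5.5-fold higher number from compound 1 to compound 3 (0.74 log units; beyond the scatter) in the two single changes. The exchange between the two methyl-bearing compounds gave an at least 2.2-fold higher number from compound 2 to compound 3 (0.35 log units; beyond the scatter) as its result. These steps bear on the change only indirectly, as a guide to how far the numbers moved for small structural changes.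

A modest step toward a lower number is therefore expected in this assay, although no step beyond the scatter remains possible. The estimate means an expected at least 1.6-fold lower number from compound 3 to compound 4 (0.22 log units; that floor lies within the scatter) on this reading. For compound 4 the expected value is 60000 nM with an estimated range from 20000 nM to 100000 nM in all.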

Compound 4, half-maximal cytotoxic concentration: 49000 nM
For compound 4 the middle estimate is 1.2-fold (0.09 log units) above the measured one, within the range that was stated.
By their numbers in this assay, from the lowest: compound 1; then compounds 2 and 4 (each within the scatter of the next). At a limit, above all of these: compound 3.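

Going by these compounds alone, the earlier steps concerned only a methyl on the shared core, so this is the first change on the carbonyl carbon whose other neighbour is the amide-type nitrogen. Compound 3 is known only as a limit in this assay: the limit of > 100000 nM in this assay, at which 1 of the 4 values shown sits.

From the compounds shown here alone, with 2-chloropyridin-3-yl in place of 3-nitrophenyl the series shows an at least 2.0-fold lower number from compound 3 to compound 4 (0.30 log units; that floor lies within the scatter), so this position now has an exact number, but the step cannot be said to exceed the scatter and its true size stays unknown.

Since the ring nitrogen and the chlorine entered together, the compounds shown do not separate their shares in the step. Going by these compounds, how a plain phenyl, a pyridine ring without chlorine or an amine on that ring would read here remains open, as does whether the same exchange would give a similar step on the core of compound 1.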